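Swapping methyl for methoxy in compound 1

A few compounds are considered here, and "the series" means these few. Any claim that something is new, unique, unknown or untested is made for them only; others in the source may bear on it.

Compound 1 `COC(=O)[C@@H](NC(=O)CSC1=C(C)C(=O)c2ccccc2C1=O)C(C)C`: 16000 nM
Compound 2 `COC(=O)[C@H](CC(C)C)NC(=O)CSC1=C(C)C(=O)c2cccc(OC)c2C1=O`: 78500 nM

In a functional assay on SAS cells (Homo sapiens) for cytotoxicity, read by MTT assay, with a stated time of 48 h (a lower number here means a stronger inhibitor, a higher number a weaker inhibitor), compound 1 gives 16000 nM, the lower of the two numbers and so the stronger result. Compound 2 gives 78500 nM, and this gap lies beyond the usual scatter. Compound 3 `COC(=O)[C@@H](NC(=O)CSC1=C(OC)C(=O)c2ccccc2C1=O)C(C)C` keeps the structure of compound 1 except for one change: methoxy in place of methyl on a double-bonded ring carbon. Among the measured compounds shown here, no two measured compounds differ in one place only, so the data offer no direct guide to the size or direction of this change. In this assay a small weakening is expected, perhaps none beyond the scatter, and the estimated step is a 1.4-fold higher number from compound 1 to compound 3 (0.14 log units; within the scatter). The estimate for compound 3 is 22000 nM, with an expected range from 7000 nM to 70000 nM.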

Compound 3, half-maximal inhibitory concentration: 56000 nM
Compound 3: the middle estimate sits 2.5-fold (0.41 log units) below what was measured; the range from low to high includes it.
By their numbers in this assay, from the lowest: compound 1; then compounds 3 and 2 (each within the scatter of the next).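

In this assay, putting methoxy in place of methyl on this double-bonded ring carbon gives a 3.5-fold higher number from compound 1 to compound 3 (0.54 log units; beyond the scatter), so this position is not indifferent to the change. The earlier compounds shown here could not show this, as compound 1 and compound 2 differ in more than one place; here a single change has been read directly, and it goes with a weaker result. Nothing at hand accounts for the direction or size of this step.

As far as these compounds go, with only methyl and methoxy at this carbon, it remains open how an ethyl group, a chlorine atom or an amine there would read in this assay on this core. Also open, from the compounds shown here alone, is whether the same swap would give a step of similar size on the core of compound 2, with its different side chain.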